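Dropping the methyl: what compound 4 may lose

The source may report more compounds than this note shows. Statements on the series, on what has been measured and on what is new or still open speak of the compounds shown alone.

Three compounds share one core and differ only in the aryl group on a double-bonded chain carbon bound to an aromatic carbon. Compound 1 `C=CCn1c(=O)/c(=C\c2cccc(F)c2)[nH]c(=O)/c1=C\c1ccccc1OC` carries a 3-fluorophenyl there, and in a functional assay on MCF7 cells (Homo sapiens) for cytotoxicity, read by CCK-8 assay, with a stated time of 72 h (a higher number here means a weaker inhibitor, a lower number a stronger inhibitor), compound 1 gives 13700 nM. Compound 2 `C=CCn1c(=O)/c(=C\c2cccc(Cl)c2Cl)[nH]c(=O)/c1=C\c1ccccc1OC` carries a 2,3-dichlorophenyl, and in this assay compound 2 gives 2100 nM. Compound 3 `C=CCn1c(=O)/c(=C\c2cc(F)ccc2C)[nH]c(=O)/c1=C\c1ccccc1OC` carries a 5-fluoro-2-methylphenyl, and in this assay compound 3 gives 3100 nM, the second highest of the three numbers; its nearest neighbour is compound 2, and the step of a 1.5-fold higher number from compound 2 to compound 3 (0.17 log units; within the scatter) is within the scatter, while the step of a 4.4-fold lower number from compound 1 to compound 3 (0.65 log units; beyond the scatter) is beyond it.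

Compound 4 `C=CCn1c(=O)/c(=C\c2ccccc2F)[nH]c(=O)/c1=C\c1ccccc1OC` is not yet measured. The change is 2-fluorophenyl in place of 5-fluoro-2-methylphenyl on a double-bonded chain carbon bound to an aromatic carbon. For the measured compounds named here, the step that bears most on it is a 4.4-fold lower number from compound 1 to compound 3 (0.65 log units; beyond the scatter), where adding a methyl lowered the number; compound 4 removes that methyl again, though the fluorine also changes its place, which no measured pair covers directly. A step back toward the number of compound 1 is therefore expected in this assay, namely a 2.6-fold higher number from compound 3 to compound 4 (0.41 log units; beyond the scatter). Compound 4 is estimated at 8000 nM, with a range from 3000 nM to 25000 nM.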

Compound 4, half-maximal inhibitory concentration: 23000 nM
Compound 4: the middle estimate sits 2.9-fold (0.46 log units) below what was measured; the measured number falls inside the stated range.
By their numbers in this assay, from the lowest: compounds 2 and 3 (each within the scatter of the next); then compounds 1 and 4 (each within the scatter of the next).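

The 2-fluorophenyl in place of 5-fluoro-2-methylphenyl gives a 7.4-fold higher number from compound 3 to compound 4 (0.87 log units; beyond the scatter) and so does more than undo the gain seen earlier, while the comparison with the 2,3-dichlorophenyl gives an 11-fold higher number from compound 2 to compound 4 (1.04 log units; beyond the scatter), the largest step in this small set. Moving to compound 4 from the 3-fluorophenyl of compound 1 gives a 1.7-fold higher number from compound 1 to compound 4 (0.23 log units; within the scatter), so in this assay these two fluorophenyl groups cannot be told apart, and the four compounds fall into two groups with no exception: the two aryl groups carrying one substituent give the higher numbers, and the two carrying two substituents give the lower numbers. Nothing shown here explains why the second substituent on this ring goes with the lower numbers.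

The compounds shown leave open whether this split depends on simply having a second substituent or on which groups those are, as every substituent on this ring so far is a halogen or a methyl. A phenyl group bearing an amine, a carboxylic acid or a longer chain at this place remains an open case, and its number could fit the split or break it.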